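A few compounds are considered here, and "the series" means these few. Any claim that something is new, unique, unknown or untested is made for them only; others in the source may bear on it.

Three compounds share one core and differ only in the group carried on the aromatic ring. Compound 1 `C(=C1\CCCN=C1c1cccnc1)\c1ccc(-n2ccnn2)cc1` gives 520 nM in an assay on membranes from brain for displacement of a labelled ligand from Neuronal acetylcholine receptor; alpha4/beta2 (Rattus norvegicus), with a stated time of 3 h; a lower number here means a stronger inhibitor, a higher number a weaker inhibitor. Compound 2 `CC(C)(C)Oc1ccc(/C=C2\CCCN=C2c2cccnc2)cc1` gives 2170 nM, and compound 3 `CC(C)(C)C(=O)Oc1ccc(/C=C2\CCCN=C2c2cccnc2)cc1` gives 830 nM. Compound 3 thus stands second highest of the three numbers, close to compound 1 and further from compound 2; the steps among them were a 1.6-fold higher number from compound 1 to compound 3 (0.20 log units; within the scatter), a 4.2-fold higher number from compound 1 to compound 2 (0.62 log units; beyond the scatter) and a 2.6-fold lower number from compound 2 to compound 3 (0.42 log units; beyond the scatter). Compound 4 `N#Cc1ccc(/C=C2\CCCN=C2c2cccnc2)cc1` carries the change (cyano in place of ((tert-butyl)carbonyl)oxy on an aromatic carbon). Going by the values given here, none of the measured steps introduces a cyano group, so none bears directly on this change; all measured steps were modest at most, so a step of similar size or none beyond the scatter is expected. The estimated step is a 1.4-fold lower number from compound 3 to compound 4 (0.14 log units; within the scatter). Compound 4 is expected to give 600 nM, within a range of 150 nM to 2500 nM.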

Compound 4, inhibition constant: 1230 nM
Compound 4: the middle estimate sits 2.1-fold (0.31 log units) below what was measured, and the stated range covers the measured number.
By their numbers in this assay, from the lowest: compounds 1, 3, 4 and 2 (each within the scatter of the next, the first and the last beyond it).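

Cyano, with 2 heavy atoms in place of the 7 of ((tert-butyl)carbonyl)oxy, stays within the scatter at this aromatic carbon, with a 1.5-fold higher number from compound 3 to compound 4 (0.17 log units; within the scatter), and also against tert-butoxy, with a 1.8-fold lower number from compound 2 to compound 4 (0.25 log units; within the scatter). Only the change from 1H-1,2,3-triazol-1-yl goes beyond the scatter, with a 2.4-fold higher number from compound 1 to compound 4 (0.37 log units; beyond the scatter), so these groups of very different size give numbers that the scatter does not separate. Nothing available accounts for this result. From the compounds shown here alone, whether an amine, a carboxylic acid or a longer chain on this carbon would stay within that scatter remains open.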